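Lengthening the Amine Chain in a Cytotoxicity Series

The source may hold more compounds than are shown below. What is called first, only, known or untested is meant among the compounds shown, and "the series" means these compounds.

Measured compounds:
compound 1, `CCNc1nc(SCC)nc2ncccc12`, 18700 nM
compound 2, `CCCCNc1nc(SCC)nc2ncccc12`, 9200 nM
compound 3, `CCCCCNc1nc(SCC)nc2ncccc12`, 1300 nM

All three share one core and differ only in the length of the chain on the amine nitrogen. In a functional assay on MDA-MB-231 cells (Homo sapiens) for cytotoxicity, read by neutral red uptake, with a stated time of 72 h (on this read-out lower numbers stand for stronger inhibition and higher numbers for weaker inhibition), compound 3 stands lowest of the three, with a 14-fold lower number from compound 1 to compound 3 (1.16 log units; beyond the scatter) and a 7.1-fold lower number from compound 2 to compound 3 (0.85 log units; beyond the scatter); the smaller step, a 2.0-fold lower number from compound 1 to compound 2 (0.31 log units; beyond the scatter), runs the same way. Compound 4, `CCCCCCNc1nc(SCC)nc2ncccc12`, carries the change (methyl in place of hydrogen on a saturated chain carbon, five bonds along the chain from a nitrogen on an aromatic ring). Going by the values given here, every step so far that lengthened this chain lowered the number, and the later steps did so more strongly than the first. A further drop is therefore expected, though nothing here shows whether the gain continues or levels off. Compound 4 is estimated at 650 nM, within 200 nM to 2500 nM. This expectation amounts to a 2.0-fold lower number from compound 3 to compound 4 (0.30 log units; within the scatter).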

Compound 4, half-maximal inhibitory concentration: 1400 nM
For compound 4 the middle estimate is 2.2-fold (0.33 log units) below the measured one; the measured number falls inside the stated range.
By their numbers in this assay, from the lowest: compounds 3 and 4 (each within the scatter of the next); then compound 2; then compound 1.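

In this assay the added methyl, five bonds along the chain from a nitrogen on an aromatic ring, gives no readable difference (a 1.1-fold higher number from compound 3 to compound 4 (0.03 log units; within the scatter)), so the earlier run of lower numbers does not carry on at this position. The longer chain of compound 4 still keeps a clear lead over the two shortest chains (a 6.6-fold lower number from compound 2 to compound 4 (0.82 log units; beyond the scatter); a 13-fold lower number from compound 1 to compound 4 (1.13 log units; beyond the scatter)). Nothing available here explains this result.

From the compounds shown here alone, whether a longer chain, such as heptyl or octyl, would match compound 4 or give a higher number remains open. So does the effect of a branched chain or a chain ending in an amine.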